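The source may hold more compounds than are shown below. What is called first, only, known or untested is meant among the compounds shown, and "the series" means these compounds.

Three compounds share one core and differ only in the aromatic group on the ether oxygen. In an assay on HEK293 cells for displacement of a labelled ligand from 5-hydroxytryptamine receptor 7 (Homo sapiens), read by radioligand binding, with a stated time of 1 h (a lower number here means a stronger inhibitor, a higher number a weaker inhibitor), compound 1 `CN1CCN(c2nc(N)nc(COc3ccccc3)n2)CC1` gives 9530 nM. Compound 2 `Cc1ccc(C(C)C)c(OCc2nc(N)nc(N3CCN(C)CC3)n2)c1` gives 12000 nM. Compound 3 `Cc1ccccc1OCc1nc(N)nc(N2CCN(C)CC2)n1` gives 514 nM, the lowest of the three numbers, reached through a 19-fold lower number from compound 1 to compound 3 (1.27 log units; beyond the scatter). Compound 4 `Cc1cc(OCc2nc(N)nc(N3CCN(C)CC3)n2)ccc1Cl` is not yet measured; it carries 4-chloro-3-methylphenyl in place of 2-methylphenyl on an oxygen on a saturated carbon. Within the data shown here, only the step from compound 1 to compound 3 touches this ring, and compound 2, with two groups on its ring, shows that more substitution does not always lower the number. Because of that single step a 19-fold lower number from compound 1 to compound 3 (1.27 log units; beyond the scatter) the estimate is wide, and the expected step is a 3.9-fold higher number from compound 3 to compound 4 (0.59 log units; beyond the scatter). Compound 4 is expected to give about 2000 nM, within 300 nM to 15000 nM.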

Compound 4, inhibition constant: 5840 nM
Compound 4: middle estimate off by 2.9-fold (0.47 log units), on the low side; low and high end bracket the measured number.
By their numbers in this assay, from the lowest: compound 3; then compounds 4, 1 and 2 (each within the scatter of the next, the first and the last beyond it).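

Putting 4-chloro-3-methylphenyl in place of 2-methylphenyl on the oxygen gives an 11-fold higher number from compound 3 to compound 4 (1.06 log units; beyond the scatter) and so shows that a methyl on the ring does not by itself keep the number low. Against plain phenyl, the same group gives a 1.6-fold lower number from compound 1 to compound 4 (0.21 log units; within the scatter) and this lies within the scatter, so compound 1 and compound 4 cannot be told apart in this assay here.

Still open, from the compounds shown here alone, is how a ring carrying a methoxy group or a lone chlorine would read. No evidence available here accounts for the difference between these rings.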